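This account rests on a few compounds, and the source may have more. Where it says the series, first, only, none or still open, it means among the compounds named here.

Compound 1, `O=S(=O)(c1cccc(Cl)c1)n1ccc2c(N3CCNCC3)cccc21`, opens the set. In an assay on HeLa cells for displacement of a labelled ligand from 5-hydroxytryptamine receptor 6 (Homo sapiens) (on this read-out lower numbers stand for stronger inhibition and higher numbers for weaker inhibition), compound 1 gives 0.251 nM. Compound 2, `O=S(=O)(c1cccc(Cl)c1)n1ccc2c(N3CCNCC3)ccc(Cl)c21`, differs from it by one change: chloro in place of hydrogen on an aromatic carbon. In this assay compound 2 gives 0.316 nM, and the step of a 1.3-fold higher number from compound 1 to compound 2 (0.10 log units; within the scatter) shows that the added chloro at that place moves the number very little. Compound 3, `O=S(=O)(c1ccccc1)n1ccc2c(N3CCNCC3)c(Cl)ccc21`, rests on a different core; the difference between the core of compound 1 and the core of compound 3 is not broken down here. In this assay compound 3 gives 1.59 nM, the highest of the three numbers, lying beyond the scatter from both compound 2 and compound 1.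

Compound 4, `O=S(=O)(c1ccccc1Cl)n1ccc2c(N3CCNCC3)c(Cl)ccc21`, has not yet been measured. It differs from compound 3 by chloro in place of hydrogen on an aromatic carbon. This is the same kind of change as from compound 1 to compound 2, but at another place: in compound 2 the chloro sits on a six-membered aromatic ring of carbon only, part of a fused or bridged system of two rings, ortho to a fused ring, meta to a fused ring and para to a piperazin-1-yl group, whereas in compound 4 it sits on a six-membered aromatic ring of carbon only, ortho to a large group.

The earlier step of a 1.3-fold higher number from compound 1 to compound 2 (0.10 log units; within the scatter) stayed within the scatter, so no large move is expected here either. A slight lowering is estimated, since compound 1, whose phenyl also bears a chloro, gives 0.251 nM while compound 3 with a bare phenyl gives 1.59 nM. The estimated step is therefore a 1.6-fold lower number from compound 3 to compound 4 (0.20 log units; within the scatter). Compound 4 is expected to give about 1 nM in this assay, between 0.3 nM and 3.2 nM.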

Compound 4, inhibition constant: 1 nM
For compound 4 middle estimate and measured number coincide at the digits printed; the range from low to high includes it.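

In this assay the new step, a 1.6-fold lower number from compound 3 to compound 4 (0.20 log units; within the scatter), is small, and set beside the earlier step on the other core it shows no difference that repeated measurement could separate: the same change on two cores in this assay, a 1.3-fold higher number (0.10 log units; within the scatter) from compound 1 to compound 2 and a 1.6-fold lower number (0.20 log units; within the scatter) from compound 3 to compound 4, 2.0-fold (0.30 log units) apart, within the scatter of two such steps Within these two pairs, then, chloro in place of hydrogen on an aromatic carbon moves the number very little on either core, and the two results agree on that point. This does not show that the change carries over unaltered from one core to another: the chloro stands at another place in each pair, so core and place shift together and their contributions cannot be told apart, and two steps of this size only show that neither pair gave a large move.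

The compounds shown leave open what the same phenyl to 2-chlorophenyl change would give on the core of compound 1, where it could be compared with the earlier step at a matching place. They also leave open how other groups would read at the place taken by the chloro in compound 4, for instance a fluoro, a methoxy or a nitrile.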